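A few compounds are considered here, and "the series" means these few. Any claim that something is new, unique, unknown or untested is made for them only; others in the source may bear on it.

Values measured in a physicochemical assay for lipophilicity; on this read-out higher numbers stand for higher lipophilicity and lower numbers for lower lipophilicity:
compound 1 `COc1cccc2c1c(NS(=O)(=O)c1ccc(Cl)s1)nn2Cc1cccc(CNC(=O)C2COC2)c1`: 4
compound 2 `COc1cccc2c1c(NS(=O)(=O)c1ccc(Cl)s1)nn2Cc1cccc(CNC(=O)C2CCO2)c1`: 4.5
compound 3 `COc1cccc2c1c(NS(=O)(=O)c1ccc(Cl)s1)nn2Cc1cc(CNC(C)=O)ccn1`: 2.6

Compound 3 has the lowest of these three numbers, clearly under those of compound 1 and compound 2. Compound 4 `COc1cccc2c1c(NS(=O)(=O)c1ccc(Cl)s1)nn2Cc1ccnc(CNC(C)=O)c1` has not been measured yet. It has the same atoms as compound 3, joined differently: 2-(acetamidomethyl)pyridin-4-yl in place of 4-(acetamidomethyl)pyridin-2-yl on a saturated chain carbon bound to an aromatic nitrogen. In words, 2-(acetamidomethyl)pyridin-4-yl takes the place of 4-(acetamidomethyl)pyridin-2-yl on a saturated chain carbon bound to an aromatic nitrogen.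

Within the data shown here, only one measured step offers a comparison, since it also swaps one arrangement of a group for another with the same atoms: a number 0.50 log units higher from compound 1 to compound 2 (beyond the scatter). This modest step concerns a different group, so it suggests a rough size but no direction. Among the measured compounds shown here, no measured pair makes the exact exchange seen here. The estimated change is therefore small, at a number 0.10 log units higher from compound 3 to compound 4 (within the scatter), and a shift of the modest size seen with the oxetanes in either direction would fit the expectation. For compound 4 the expected value is 2.7, with an estimated range from 2.2 to 3.2.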

Compound 4, distribution coefficient: 2.5
Compound 4: middle estimate off by 0.20 log units, on the high side, within the range that was stated.
By their numbers in this assay, from the lowest: compounds 4 and 3 (each within the scatter of the next); then compound 1; then compound 2.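

In this assay, exchanging 4-(acetamidomethyl)pyridin-2-yl for 2-(acetamidomethyl)pyridin-4-yl on a saturated chain carbon bound to an aromatic nitrogen gives a number 0.10 log units lower from compound 3 to compound 4 (within the scatter). This exchange keeps the same atoms, and the read-out does not distinguish the two arrangements, whereas the oxetane exchange gave a number 0.50 log units higher from compound 1 to compound 2 (beyond the scatter). Nothing available explains why these two exchanges of atoms differ in outcome.

The compounds shown leave open whether the pyridine exchange would remain within the scatter if a primary amine or a carboxylic acid took the place of the acetamide, or if a longer chain carried the amide. They also leave open whether the two arrangements would match on any read-out other than this assay.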